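Removing the para chloro group: compound 3 to compound 4

A few compounds are considered here, and "the series" means these few. Any claim that something is new, unique, unknown or untested is made for them only; others in the source may bear on it.

Compound 1 `Cc1ccc(Nc2nc(SCc3cn(CC(=O)NC(=O)Nc4ccccn4)nn3)nc(-c3ccc(C(C)C)cc3)c2C#N)cc1` gives 3360 nM in a functional assay on MGC-803 cells (Homo sapiens) for inhibition, read by MTT assay, with a stated time of 72 h; on this read-out higher numbers stand for weaker inhibition and lower numbers for stronger inhibition. Compound 2 `Cc1ccc(Nc2nc(SCc3cn(CC(=O)NC(=O)Nc4ccccn4)nn3)nc(-c3ccc(Br)cc3)c2C#N)cc1` gives 13900 nM in this assay, and compound 3 `Cc1ccc(Nc2nc(SCc3cn(CC(=O)NC(=O)Nc4ccccn4)nn3)nc(-c3ccc(Cl)cc3)c2C#N)cc1` gives 24000 nM in this assay, the highest of the three numbers; the gap from compound 2 to compound 3 lies within the scatter, so no order between those two can be read. The measured steps show a 4.1-fold higher number from compound 1 to compound 2 (0.62 log units; beyond the scatter) and a 7.1-fold higher number from compound 1 to compound 3 (0.85 log units; beyond the scatter), while a 1.7-fold higher number from compound 2 to compound 3 (0.24 log units; within the scatter) stays within the scatter.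

Compound 4 `Cc1ccc(Nc2nc(SCc3cn(CC(=O)NC(=O)Nc4ccccn4)nn3)nc(-c3ccccc3)c2C#N)cc1` differs from compound 3 by hydrogen in place of chloro on an aromatic carbon. Among the compounds with values here, none of the measured steps removes a halogen outright; the closest evidence is that swapping one halogen for the other changed little, whereas exchanging the isopropyl for either halogen weakened inhibition. Compound 4 is therefore expected to stay close to compound 3, with a step of a 1.3-fold higher number from compound 3 to compound 4 (0.10 log units; within the scatter) that is unlikely to exceed the scatter. The estimate for compound 4 in this assay is 30000 nM, with a range from 12000 nM to 75000 nM.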

Compound 4, half-maximal inhibitory concentration: 7870 nM
The estimate for compound 4 lay 3.8-fold (0.58 log units) above the measured number, outside the stated range (below it).
By their numbers in this assay, from the lowest: compound 1; then compounds 4, 2 and 3 (each within the scatter of the next, the first and the last beyond it).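

The chloro group at this position does not help inhibition: a 3.0-fold lower number from compound 3 to compound 4 (0.48 log units; beyond the scatter), so the plain phenyl is not the poor baseline that the halogen results alone might have suggested. Hydrogen in place of bromo gives a 1.8-fold lower number from compound 2 to compound 4 (0.25 log units; within the scatter), which separates compound 4 from compound 2 by no more than the scatter, while a 2.3-fold higher number from compound 1 to compound 4 (0.37 log units; beyond the scatter) shows that the isopropyl group keeps a real advantage over hydrogen as well as over both halogens, making compound 1 the strongest of the four. No independent measurement bears on why these steps run as they do.

Whether that advantage belongs to the isopropyl group alone stays open, since a methyl, an ethyl or a tert-butyl group at this position is not among the compounds shown. On these data alone, a methoxy or an amino group there is equally absent, so the response to such groups remains unknown.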